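Methoxy added on the aromatic ring of compound 2

The source may hold more compounds than are shown below. What is called first, only, known or untested is meant among the compounds shown, and "the series" means these compounds.

Measured in an assay on isolated protein for inhibition of Nitric oxide synthase, inducible (Homo sapiens), with a stated time of 30 min, tested at 1 mM; on this read-out higher numbers stand for more inhibition at the one concentration tested (going by the name of the read-out) and lower numbers for less inhibition:
compound 1 `COc1ccc(N)c(C2=NN(C(C)=O)CC2)c1` — 20.4%
compound 2 `COc1ccc(N)c(C2=NN(C(=O)c3ccccc3)CC2)c1` — 12.2%

Among the measured compounds shown here, only one step separates the two measured compounds: a number 8.2 percentage points lower from compound 1 to compound 2 (within the scatter), phenyl in place of methyl on a carbonyl carbon. Compound 2 holds the lowest of the two numbers, with compound 1 nearest and within the scatter, so no order between them can be read from these values.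

Compound 3 `COc1cc(N)c(C2=NN(C(=O)c3ccccc3)CC2)cc1OC` differs from compound 2 by methoxy in place of hydrogen on an aromatic carbon. For the measured compounds named here, no measured step touches the six-membered aromatic ring of carbon only; the single step on record sits at the carbonyl and was itself within the scatter, so it gives no direct guidance for this change. With nothing pointing to a shift beyond the scatter, compound 3 is expected to stay close to its parent, the expected step being a number 1.8 percentage points higher from compound 2 to compound 3 (within the scatter). For compound 3 the estimate is 14%, within 0% to 32%.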

Compound 3, a percentage reported as inhibition, at one concentration (the size of the read-out at that concentration, not a potency): 28.9%
Compound 3: the middle estimate sits 14.9 percentage points below what was measured; low and high end bracket the measured number.
By their numbers in this assay, from the lowest: compounds 2, 1 and 3 (each within the scatter of the next, the first and the last beyond it).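

In this assay, among the compounds shown here, methoxy in place of hydrogen on the aromatic carbon ortho to a methoxy group, meta to an amino group and para to a large group gives a number 16.7 percentage points higher from compound 2 to compound 3 (beyond the scatter), the only step so far that lies beyond the scatter. The one earlier step, at the carbonyl, stayed within the scatter, so this aromatic position is the only place shown where a change moves the read-out, and the shift is modest and rests on a single tested concentration. Nothing on hand accounts for the rise.

Going by these compounds, whether an ethoxy, a hydroxyl or a fluorine at this position would give a similar step remains open. Also open, on these data alone, is whether the same methoxy gives this step with methyl in place of phenyl on the carbonyl carbon.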